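The source may report more compounds than this note shows. Statements on the series, on what has been measured and on what is new or still open speak of the compounds shown alone.

Compound 1 `Cn1ncc(Cl)c1-c1cc(C(=O)N[C@@H]2CN[C@H](CCn3cncn3)C[C@H]2c2ccc(Cl)c(Cl)c2)oc1Cl` is the reference point of this series. In a functional assay on HCT-116 cells (Homo sapiens) for antiproliferative activity, read by sulforhodamine B assay, with a stated time of 72 h (on this read-out lower numbers stand for stronger inhibition and higher numbers for weaker inhibition), compound 1 gives 560 nM. Compound 2 `CNC(=O)C[C@@H]1C[C@@H](c2ccc(F)c(F)c2)[C@H](NC(=O)c2cc(-c3c(Cl)cnn3C)c(Cl)o2)CN1`, which carries a different pattern of substituents, gives 1100 nM in this assay, and the gap between the two values lies within the usual scatter, so the two compounds cannot be told apart on these numbers. Compound 3 `Cn1ncc(Cl)c1-c1cc(C(=O)N[C@@H]2CN[C@H](CC(=O)NCCO)C[C@H]2c2ccc(Cl)c(Cl)c2)oc1Cl` has not yet been measured in this assay. It differs from compound 1 in one place: (2-hydroxyethyl)carbamoyl in place of (1H-1,2,4-triazol-1-yl)methyl on a saturated chain carbon bound to a saturated ring carbon. Within the data shown here, no measured pair shows this kind of change, so no size of step beyond the scatter can be read from the data. Compound 3 is therefore expected to give a number close to that of compound 1, with a step of a 1.3-fold higher number from compound 1 to compound 3 (0.13 log units; within the scatter) estimated as little more than the scatter. The estimate for compound 3 in this assay is 750 nM, expected to lie between 250 nM and 2200 nM.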

Compound 3, half-maximal inhibitory concentration: 670 nM
Compound 3: the middle estimate sits 1.1-fold (0.05 log units) above what was measured; measured number inside the range.
By their numbers in this assay, from the lowest: compounds 1, 3 and 2 (each within the scatter of the next).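

In this assay, the exchange of (1H-1,2,4-triazol-1-yl)methyl for (2-hydroxyethyl)carbamoyl on a saturated chain carbon bound to a saturated ring carbon gives the first step measured at this position, a 1.2-fold higher number from compound 1 to compound 3 (0.08 log units; within the scatter). The two groups cannot be told apart on this read-out, so here a group with no ring stands in for one with a five-membered aromatic ring without a step beyond the scatter. Going by these compounds, whether an amine, a carboxylic acid or a longer chain at this place would behave the same remains open. No supporting measurement accounts for this result.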